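From thiophen-3-yl to ethynyl on the shared core

This account rests on a few compounds, and the source may have more. Where it says the series, first, only, none or still open, it means among the compounds named here.

In a functional assay on K562 cells (Homo sapiens), read by MTT assay, with a stated time of 72 h (a higher number here means a weaker inhibitor, a lower number a stronger inhibitor), compound 3 (`COc1nc(N)nc2c1c(-c1ccsc1)cn2[C@@H]1O[C@H](CO)[C@@H](O)[C@H]1O`) gives only a limit (> 20000 nM), not a number. Compound 2 (`COc1nc(N)nc2c1c(-c1ccco1)cn2[C@@H]1O[C@H](CO)[C@@H](O)[C@H]1O`) also gives only a limit (> 20000 nM). Compound 3 therefore offers no exact starting point, and the two cannot be ranked.

Compound 4 (`C#Cc1cn([C@@H]2O[C@H](CO)[C@@H](O)[C@H]2O)c2nc(N)nc(OC)c12`) carries ethynyl in place of thiophen-3-yl on an aromatic carbon. Among the compounds with values here, the one measured step in this part of the series (a step that the two limits leave unreadable from compound 2 to compound 3) gives no size to carry over. Within the data shown here, the only numerical guide is compound 1 (`C#Cc1cn([C@@H]2O[C@H](CO)[C@@H](O)[C@H]2O)c2ncnc(OC)c12`), which also bears ethynyl and gives a measured value in this assay (300 nM). As this is a single compound, the guide is loose, and a further limit remains possible.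

On the value of compound 1 (300 nM), stronger inhibition than that of compound 3 is expected for compound 4. The expected step (an at least 6.6-fold lower number from compound 3 to compound 4 (0.82 log units; beyond the scatter)) points toward stronger inhibition. For compound 4 the estimated value is 3000 nM (expected range 400 nM to 20000 nM).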

Compound 4, half-maximal inhibitory concentration: > 20000 nM
Compound 4 gave a limit, no number; the forecaster's own chance of this, stated with the estimate: 25%; middle value at least 6.6-fold (0.82 log units) from the limit.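

Compound 4 gives only a limit in this assay, not a number, so ethynyl at this position does not by itself keep a measurable value on the shared core. Amino in place of hydrogen on an aromatic carbon, with ethynyl unchanged, gives an at least 66-fold higher number from compound 1 to compound 4 (1.82 log units; beyond the scatter), the only readable step in this set and one that is beyond the scatter. The steps among compounds 2, 3 and 4 cannot be read, which leaves furan-2-yl, thiophen-3-yl and ethynyl unranked when the amino group is present: the limit of > 20000 nM in this assay, at which 3 of the 4 values shown sit.

Going by these compounds, it remains open whether a methylamino or hydroxyl group in place of the amino group would give a number with ethynyl retained. On these data alone, how furan-2-yl or thiophen-3-yl would read on the core of compound 1, which lacks the amino group, also remains open.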